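Ester variation on the shared core of compound 1

The source may hold more compounds than are shown below. What is called first, only, known or untested is meant among the compounds shown, and "the series" means these compounds.

The series shares the core of compound 1 `C=C1C(=O)[C@@]23C(=O)OC[C@]4(C(=O)CCC(C)(C)[C@H]4C=O)[C@@H]2CC[C@@H]1[C@H]3OC(C)=O` and varies only the ester group on the carbonyl carbon. In a functional assay on Bel-7402 cells (Homo sapiens) for cytotoxicity, read by MTT assay, with a stated time of 72 h (on this read-out higher numbers stand for weaker inhibition and lower numbers for stronger inhibition), compound 1 gives 1730 nM, the higher of the two numbers recorded so far, although its separation from compound 2 lies within the scatter. Compound 2 `C=C1C(=O)[C@@]23C(=O)OC[C@]4(C(=O)CCC(C)(C)[C@H]4C=O)[C@@H]2CC[C@@H]1[C@H]3OC(=O)c1ccc(C)cc1` carries 4-methylphenyl in place of methyl on that carbonyl carbon; in this assay compound 2 gives 1540 nM, and the step of a 1.1-fold lower number from compound 1 to compound 2 (0.05 log units; within the scatter) stays within the scatter. Compound 3 `C=C1C(=O)[C@@]23C(=O)OC[C@]4(C(=O)CCC(C)(C)[C@H]4C=O)[C@@H]2CC[C@@H]1[C@H]3OC(=O)c1ccc([N+](=O)[O-])cc1` is the next ester: 4-nitrophenyl in place of methyl on a carbonyl carbon. Within the data shown here, the only measured step that bears on this change, a 1.1-fold lower number from compound 1 to compound 2 (0.05 log units; within the scatter), shows that exchanging methyl for a six-membered aromatic ring at this carbonyl carbon moved the read-out by less than the scatter; no measured compound carries 4-nitrophenyl, so nothing is known of that substituent here. The expected step is therefore a 1.2-fold lower number from compound 1 to compound 3 (0.06 log units; within the scatter), none beyond the scatter. Compound 3 is estimated at 1500 nM, within 600 nM to 3800 nM.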

Compound 3, half-maximal inhibitory concentration: 3300 nM
For compound 3 the middle estimate is 2.2-fold (0.34 log units) below the measured one; the measured number falls inside the stated range.
By their numbers in this assay, from the lowest: compounds 2, 1 and 3 (each within the scatter of the next, the first and the last beyond it).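

In this assay this position first gives a separation beyond the scatter: nitro in place of methyl on an aromatic carbon gives a 2.1-fold higher number from compound 2 to compound 3 (0.33 log units; beyond the scatter) and counts as a modest step. The substituent on the six-membered aromatic ring can therefore register in this read-out, which the exchange of methyl for the ring itself did not show. Taken from the other side, 4-nitrophenyl in place of methyl on a carbonyl carbon gives a 1.9-fold higher number from compound 1 to compound 3 (0.28 log units; within the scatter) and so stays unresolved, and nothing on hand bears on the reason for either step.

On these data alone, whether an amine or a methoxy group on that same aromatic carbon would follow nitro or methyl remains open. Also open, as far as these compounds go, is how a longer alkyl chain in place of methyl on the carbonyl carbon would read.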